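Hydroxy step on the core of compound 1

The source may report more compounds than this note shows. Statements on the series, on what has been measured and on what is new or still open speak of the compounds shown alone.

Measured in a functional assay on DWD cells (Homo sapiens) for inhibition, read by sulforhodamine B assay; a higher number here means a weaker inhibitor of growth, a lower number a stronger inhibitor of growth:
compound 1 `c1ccc(-c2ccc(-c3ccc(-c4nc5ccccc5[nH]4)cc3)cc2)cc1`: 100000 nM
compound 2 `CN(C)c1ccc(-c2ccc(-c3ccc(-c4nc5ccccc5[nH]4)cc3)cc2)cc1`: 100000 nM

In this assay compound 2 stands level with compound 1 at 100000 nM. Compound 3 `Oc1cccc2[nH]c(-c3ccc(-c4ccc(-c5ccccc5)cc4)cc3)nc12` is not yet measured and differs from compound 1 by hydroxy in place of hydrogen on an aromatic carbon. Going by the values given here, the only measured step is no change at the digits printed from compound 1 to compound 2 (within the scatter). Among the compounds with values here, that step concerns dimethylamino, so it bears on hydroxy only indirectly, and no measured compound carries hydroxy. No shift beyond the scatter is therefore expected in this assay, though any shift would more likely be towards stronger inhibition. The expected result is a 1.4-fold lower number from compound 1 to compound 3 (0.15 log units; within the scatter). For compound 3 the estimate is 70000 nM, with an expected range of 20000 nM to 120000 nM.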

Compound 3, concentration for 50% growth inhibition: 9680 nM
Compound 3: the middle estimate sits 7.2-fold (0.86 log units) above what was measured; the measured number lies below the stated range.
By their numbers in this assay, from the lowest: compound 3; then compounds 1 and 2 (each within the scatter of the next).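

Hydroxy in place of hydrogen on an aromatic carbon, ortho to a fused ring and meta to a fused ring, gives in this assay a 10-fold lower number from compound 1 to compound 3 (1.01 log units; beyond the scatter) and so shows that growth inhibition on the core of compound 1 can respond to a single added group. The dimethylamino step, by contrast, gave no change at the digits printed from compound 1 to compound 2 (within the scatter) at a different place on the core. Nothing measured here explains the hydroxy result.

Whether this gain is specific to hydroxy remains open, since methoxy or an amine at the same carbon is not among the compounds shown. Also open, as far as these compounds go, is whether hydroxy elsewhere on the same ring would give a similar step.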